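Replacing the aryl amine with a pyrazole bearing a carboxymethyl group

A few compounds are considered here, and "the series" means these few. Any claim that something is new, unique, unknown or untested is made for them only; others in the source may bear on it.

Of the compounds shown here, two sharing one core have been measured in a functional assay on HCT-116 cells (Homo sapiens) for antiproliferative activity, read by sulforhodamine B assay, with a stated time of 72 h; a higher number here means a weaker inhibitor, a lower number a stronger inhibitor. Compound 1 `COc1ncc(-c2ccc3ncnc(Nc4ccc(OCCCO)nc4)c3c2)cc1NS(=O)(=O)c1ccc(F)cc1F` gives 3680 nM. Among the compounds with values here, compound 2 `COc1ncc(-c2ccc3ncnc(Nc4ccc(OCCO)c(F)c4)c3c2)cc1NS(=O)(=O)c1ccc(F)cc1F` gives 9160 nM, the higher of the two numbers; the only step between them, a 2.5-fold higher number from compound 1 to compound 2 (0.40 log units; beyond the scatter), is modest but beyond the scatter, so compound 2 stands as the weaker inhibitor of the pair.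

Compound 3 `COc1ncc(-c2ccc3ncnc(Nc4cnn(CC(=O)O)c4)c3c2)cc1NS(=O)(=O)c1ccc(F)cc1F` is not yet measured. It differs from compound 2 by 1-(carboxymethyl)-1H-pyrazol-4-yl in place of 3-fluoro-4-(2-hydroxyethoxy)phenyl on a nitrogen on an aromatic ring. Within the data shown here, no measured step covers this kind of change: the one step available, from compound 1 to compound 2, swaps two six-membered rings on the same nitrogen and moved the number only modestly. The new group is a five-membered ring carrying a carboxylic acid, a larger departure than anything measured here, so the direction is uncertain and the range must be wide. Compound 3 is therefore estimated at 9000 nM, within a range of 2000 nM to 30000 nM. The expected step in this assay is a 1.0-fold lower number from compound 2 to compound 3 (0.01 log units; within the scatter), leaning towards a weaker inhibitor.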

Compound 3, half-maximal inhibitory concentration: 1540 nM
Compound 3: the middle estimate sits 5.8-fold (0.77 log units) above what was measured, and the stated range ends above it.
By their numbers in this assay, from the lowest: compound 3; then compound 1; then compound 2.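

Bringing in 1-(carboxymethyl)-1H-pyrazol-4-yl on the nitrogen gives a 5.9-fold lower number from compound 2 to compound 3 (0.77 log units; beyond the scatter) and also a 2.4-fold lower number from compound 1 to compound 3 (0.38 log units; beyond the scatter) in this assay and this makes compound 3 the strongest inhibitor of the three. The position therefore does not depend on a six-membered aromatic ring carrying a hydroxy-ended chain: a five-membered aromatic ring with 2 hetero atoms and a carboxymethyl group gives a lower number than both of the six-membered groups in compound 1 and compound 2. Nothing available here explains why the number falls with this change.

The ring and the carboxylic acid change together in compound 3, so these compounds cannot show which of the two accounts for the lower number. Going by these compounds, a pyrazole carrying a 2-hydroxyethyl group or a methyl ester in place of the carboxymethyl group, or a phenyl ring carrying the carboxymethyl group, would separate the two parts, and the effect of a longer chain ending in a carboxylic acid also remains open.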